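The source may hold more compounds than are shown below. What is called first, only, known or untested is meant among the compounds shown, and "the series" means these compounds.

Measured so far in an assay on isolated protein for inhibition of Calpain-1 catalytic subunit (Sus scrofa), read by FRET; a higher number here means a weaker inhibitor, a lower number a stronger inhibitor:
- compound 1 `O=C(O)/C(S)=C/c1c[nH]c2ccc(F)cc12`: 800 nM
- compound 2 `O=C(O)/C(S)=C/c1cccc(F)c1`: 19000 nM

Compound 2 stands at the highest of the two numbers; compound 1 sits far lower, a gap beyond the usual scatter. Compound 3 `O=C(O)/C(S)=C/c1cccc(Cl)c1` differs from compound 2 by chloro in place of fluoro on an aromatic carbon. Among the measured compounds shown here, no measured pair covers this exchange, so only a small step is expected, leaning toward a lower number yet possibly within the scatter. In this assay compound 3 is expected to give 12000 nM, range 4000 nM to 40000 nM. That estimate means an expected step of a 1.6-fold lower number from compound 2 to compound 3 (0.20 log units; within the scatter).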

Compound 3, half-maximal inhibitory concentration: 4200 nM
Compound 3: the middle estimate sits 2.9-fold (0.46 log units) above what was measured, and the stated range covers the measured number.
By their numbers in this assay, from the lowest: compound 1; then compound 3; then compound 2.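

In this assay, among the compounds shown here, the halogen on this aromatic carbon affects the read-out: chloro in place of fluoro gives a 4.5-fold lower number from compound 2 to compound 3 (0.66 log units; beyond the scatter) in the first single-place exchange of the series. The position is therefore sensitive to a one-atom change, which the earlier comparison across different cores could not show. No measurement here bears on why this step arises.

As far as these compounds go, whether the trend extends to bromo or methyl at this place remains open, as does the effect of a hydroxyl or an amine there. From the compounds shown here alone, the same exchange on the core of compound 1 is also open.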